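The compounds below may be only part of what the source reports. "The series", "measured", "known", "first", "only" and "open" are said of these compounds alone.

Compound 1 `Cc1ccc(NC(=O)CCC(=O)OCCCCCCSc2ccc([N+](=O)[O-])c3nonc23)cc1` gives 2340 nM
Compound 2 `COc1ccc(NC(=O)CCC(=O)OCCCCCCSc2ccc([N+](=O)[O-])c3nonc23)cc1` gives 1590 nM

In an ADME assay on HUVEC cells (Homo sapiens) for cytotoxicity, read by MTT assay, with a stated time of 72 h (on this read-out higher numbers stand for weaker inhibition and lower numbers for stronger inhibition), compound 2 at 1590 nM stands level with compound 1 at 2340 nM since the two values lie within the scatter of each other. The unmeasured compound 3 `CN(C)CCNC(=O)CCC(=O)OCCCCCCSc1ccc([N+](=O)[O-])c2nonc12` differs from compound 2 by 2-(dimethylamino)ethyl in place of 4-methoxyphenyl on an amide-type nitrogen with 2-(dimethylamino)ethyl in place of 4-methoxyphenyl on an amide-type nitrogen. Among the measured compounds shown here, the one measured step of a 1.5-fold lower number from compound 1 to compound 2 (0.17 log units; within the scatter) is methoxy in place of methyl on an aromatic carbon. For the measured compounds named here, it bears on this change only weakly, as no measured compound lacks an aromatic ring on that nitrogen, so the data give no size for the swap. The expected step is a 1.3-fold higher number from compound 2 to compound 3 (0.10 log units; within the scatter) and no move beyond the scatter is expected, though with wide uncertainty. In this assay the estimate for compound 3 is 2000 nM with an expected range of 700 nM to 6000 nM for now.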

Compound 3, half-maximal inhibitory concentration: 2160 nM
Compound 3: middle estimate off by 1.1-fold (0.03 log units), on the low side, within the range that was stated.
By their numbers in this assay, from the lowest: compounds 2, 3 and 1 (each within the scatter of the next).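

In this assay, an open chain on the amide-type nitrogen in place of the aromatic group leaves the number within the scatter (a 1.4-fold higher number from compound 2 to compound 3 (0.13 log units; within the scatter); a 1.1-fold lower number from compound 1 to compound 3 (0.03 log units; within the scatter)). Among the compounds shown here, until now this position had been seen only with a substituted phenyl ring, and 2-(dimethylamino)ethyl, which carries no ring and has fewer heavy atoms than 4-methoxyphenyl, gives no move beyond the scatter against either aryl compound. No supporting measurement explains this level result.

Going by these compounds, it remains open whether a longer chain ending in the same dimethylamino group, a morpholine in its place or a terminal carboxylic acid would shift the number beyond the scatter. The ester and the shared core stay the same in all three compounds, so changes at those sites also remain unresolved.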